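The source may report more compounds than this note shows. Statements on the series, on what has been measured and on what is new or still open speak of the compounds shown alone.

Measured compounds:
Compound 1, `Fc1cccc(Cl)c1-c1cc(-c2cnn(C3CCNCC3)c2)on1`: 48 nM
Compound 2, `Clc1cnccc1-c1cc(-c2cnn(C3CCNCC3)c2)on1`: 200 nM
Compound 3, `Clc1cccc(Cl)c1-c1cc(-c2cnn(C3CCNCC3)c2)on1`: 410 nM

All three numbers come from an assay on isolated protein for positive allosteric modulation of Neuronal acetylcholine receptor; alpha4/beta2 (Homo sapiens); a higher number here means that more compound is needed for the effect, a lower number that less compound is needed. Compound 3 carries the highest number of the three: in this assay compound 3 gives 410 nM, with compound 2 nearest, a 2.1-fold higher number from compound 2 to compound 3 (0.31 log units; beyond the scatter), and compound 1 furthest away, an 8.5-fold higher number from compound 1 to compound 3 (0.93 log units; beyond the scatter).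

Compound 4, `c1nn(C2CCNCC2)cc1-c1cc(C2CCCCC2)no1`, is not yet measured. It differs from compound 3 in one place: cyclohexyl in place of 2,6-dichlorophenyl on an aromatic carbon. Among the measured compounds shown here, none of the measured steps swaps a six-membered aromatic ring for a non-aromatic one, so no step bears on this change directly. The two steps that do exchange the group at this position, a 4.2-fold higher number from compound 1 to compound 2 (0.62 log units; beyond the scatter) and a 2.1-fold higher number from compound 2 to compound 3 (0.31 log units; beyond the scatter), were modest, and every exchange here so far moved the number beyond the scatter; the present change is a larger departure than any of them. A higher number for compound 4 than for compound 3 is therefore expected, a 3.7-fold higher number from compound 3 to compound 4 (0.56 log units; beyond the scatter), with wide uncertainty. The estimate for compound 4 in this assay is 1500 nM, expected to lie between 300 nM and 8000 nM.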

Compound 4, half-maximal effective concentration: 4600 nM
For compound 4 the middle estimate is 3.1-fold (0.49 log units) below the measured one; the measured number falls inside the stated range.
By their numbers in this assay, from the lowest: compound 1; then compound 2; then compound 3; then compound 4.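

Cyclohexyl, the only non-aromatic ring at this position so far, gives an 11-fold higher number from compound 3 to compound 4 (1.05 log units; beyond the scatter) and a 23-fold higher number from compound 2 to compound 4 (1.36 log units; beyond the scatter) and a 96-fold higher number from compound 1 to compound 4 (1.98 log units; beyond the scatter) in this assay and all three steps are large, whereas exchanges among the three aromatic groups were modest. Among these four compounds, then, each aromatic group gives a lower number than cyclohexyl, even though all four groups are six-membered rings. Cyclohexyl also carries no chlorine, so losing the aromatic ring and losing the chlorine cannot be told apart here, and nothing available explains the rise.

Plain phenyl, with no chlorine, would help separate those two changes. On these data alone, how a smaller ring such as cyclopropyl or an open chain such as tert-butyl would behave at this position also remains open.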